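Adding one methoxy to compound 3

This account rests on a few compounds, and the source may have more. Where it says the series, first, only, none or still open, it means among the compounds named here.

Measured in a functional assay on HepG2 cells (Homo sapiens) for antiproliferative activity, read by sulforhodamine B assay, with a stated time of 48 h (a lower number here means a stronger inhibitor, a higher number a weaker inhibitor), so far:
- compound 1 `COc1cccc(/C=C/C(=O)/C=C(O)/C=C/c2cccc(OC)c2OC)c1OC` gives 12900 nM
- compound 2 `COc1cccc(/C=C/C(=O)C(=Cc2ccc(F)cc2)C(=O)/C=C/c2cccc(OC)c2OC)c1OC` gives 580 nM
- compound 3 `COc1cccc(C=C(C(=O)/C=C/c2cccc(OC)c2OC)C(=O)/C=C/c2cccc(OC)c2OC)c1OC` gives 230 nM

Compound 3 has the lowest number of the three, and its gaps to compound 1 and compound 2 both lie beyond the scatter. The next compound to be tested is compound 4 `COc1cccc(/C=C/C(=O)C(=Cc2ccc(OC)c(OC)c2OC)C(=O)/C=C/c2cccc(OC)c2OC)c1OC` and it differs from compound 3 in one place: methoxy in place of hydrogen on an aromatic carbon is the whole change. A methoxy takes the place of hydrogen on an aromatic carbon, turning 2,3-dimethoxyphenyl into 2,3,4-trimethoxyphenyl.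

Going by the values given here, only one measured step bears on this. It is a 2.5-fold lower number from compound 2 to compound 3 (0.40 log units; beyond the scatter) and it came from putting 2,3-dimethoxyphenyl in place of 4-fluorophenyl on the same double-bonded chain carbon. That step was modest, and one step is thin evidence. Adding a single methoxy is a smaller edit than that swap, so in this assay no step beyond the scatter is expected, and no direction can be firmly predicted. The estimate means a 1.2-fold higher number from compound 3 to compound 4 (0.09 log units; within the scatter) as the expected outcome. For compound 4 the estimated value is 280 nM with an expected range from 100 nM to 750 nM overall.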

Compound 4, half-maximal inhibitory concentration: 240 nM
For compound 4 the middle estimate is 1.2-fold (0.07 log units) above the measured one; measured number inside the range.
By their numbers in this assay, from the lowest: compounds 3 and 4 (each within the scatter of the next); then compound 2; then compound 1.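

In this assay a methoxy on this aromatic carbon, ortho to a methoxy group and para to a large group, gives a 1.0-fold higher number from compound 3 to compound 4 (0.02 log units; within the scatter) and so leaves the two compounds indistinguishable, showing that this carbon can carry the extra methoxy with no measurable difference in this cell test. The comparison with the fluorinated compound gives a 2.4-fold lower number from compound 2 to compound 4 (0.38 log units; beyond the scatter) and so stays beyond the scatter, which means that the 2,3-dimethoxyphenyl and 2,3,4-trimethoxyphenyl compounds both keep their modest separation from the 4-fluorophenyl compound. No measurement shown here explains why the added methoxy makes no detectable difference.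

What the compounds shown leave open is whether this tolerance extends beyond methoxy, for example to an amine, a carboxylic acid or a longer chain such as butoxy on the same carbon. They also leave open whether either methoxy already on this ring is needed, as a ring carrying only the new methoxy would be required to answer that.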